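Methyl in place of acetyl on the shared core

The compounds below may be only part of what the source reports. "The series", "measured", "known", "first", "only" and "open" are said of these compounds alone.

Compound 1, `Cc1nn(C(=O)c2cccnc2)c(N)c1-c1ccc(Cl)c(Cl)c1`: in an assay on Sf9 cells for inhibition of mitogen-activated protein kinase kinase kinase 14 (Homo sapiens), read by ADP-Glo, with a stated time of 60 min (on this read-out higher numbers stand for weaker inhibition and lower numbers for stronger inhibition), compound 1 gives > 100000 nM, which is a limit of the assay and not a number.
Compound 2, `CC(=O)n1nc(N)c(-c2ccc(Cl)c(Cl)c2)c1C`: in this assay compound 2 gives > 100000 nM, again a limit.
Compound 3, `Cc1c(-c2ccc(Cl)c(Cl)c2)c(N)nn1C(=O)c1cccnc1`: in this assay compound 3 gives > 100000 nM, also a limit.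

Compound 2 therefore stands nowhere that can be pinned down: its value is a limit, and the two other values shown are limits as well, all three sitting at the limit of > 100000 nM in this assay, at which 3 of the 3 values shown sit. Going by the values given here, the one measured step between compounds that differ in a single place, a step that the two limits leave unreadable from compound 2 to compound 3, cannot be read in size or direction, because both of its ends rest on (the limit of > 100000 nM in this assay, at which 3 of the 3 values shown sit).

Compound 4, `Cc1c(-c2ccc(Cl)c(Cl)c2)c(N)nn1C`, differs from compound 2 by methyl in place of acetyl on an aromatic nitrogen. Among the compounds with values here, no measured step concerns this change, and the only measured step at all is unreadable, so the measured evidence gives no reason to expect a movement beyond the scatter in either direction. It is therefore expected that compound 4 will again sit at or near the limit, with an estimate of 100000 nM and a range from 30000 nM to 300000 nM. The step of a number no higher from compound 2 to compound 4 (the limit leaves the size open) is accordingly expected to be no real change.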

Compound 4, half-maximal inhibitory concentration: > 100000 nM
Compound 4: a limit, no number (the forecaster's own chance of this, stated with the estimate: 80%); the middle value sits exactly at the limit.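

In this assay compound 4 gives > 100000 nM, which is a limit of the assay and not a number. The comparison of compound 2 with compound 4 therefore cannot be read in size or direction, since both ends are limits: the limit of > 100000 nM in this assay, at which 4 of the 4 values shown sit.

The compounds shown leave open whether any change on the shared core gives a measurable inhibition.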